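Aryl-to-alkyl swap on the amine chain of a diarylmethyl ether series

The compounds below may be only part of what the source reports. "The series", "measured", "known", "first", "only" and "open" are said of these compounds alone.

Measured so far:
compound 1, `COc1ccc(CCCN2CCC(COC(c3ccc(Br)cc3)c3ccc(Br)cc3)CC2)cc1`, 3200 nM
compound 2, `Clc1ccc(CCCN2CCC(COC(c3ccccc3)c3ccccc3)CC2)cc1`, 500 nM

In a functional assay on cells (T-cell line, Homo sapiens) for inhibition (a lower number here means a stronger inhibitor, a higher number a weaker inhibitor), compound 2 gives 500 nM, the lowest of the two numbers in hand. Among the measured compounds shown here, the only other measured compound, compound 1, gives 3200 nM, a gap that lies beyond the scatter, though the two compounds differ in more than one place and no single step can be drawn between them.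

Compound 3, `CCCCCCN1CCC(COC(c2ccccc2)c2ccccc2)CC1`, has not been measured. It differs from compound 2 in one place: propyl in place of 4-chlorophenyl on a saturated chain carbon, three bonds along the chain from an amine nitrogen in a ring.

For the measured compounds named here, no step between measured compounds bears on this change, so the expectation rests on the structures alone. The step from compound 2 to compound 3 is expected to go toward a higher number, beyond the scatter, estimated as a 4.0-fold higher number from compound 2 to compound 3 (0.60 log units; beyond the scatter). For compound 3 the estimate is 2000 nM, with a range from 600 nM to 7000 nM.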

Compound 3, half-maximal inhibitory concentration: 5500 nM
Compound 3: middle estimate off by 2.8-fold (0.44 log units), on the low side; measured number inside the range.
By their numbers in this assay, from the lowest: compound 2; then compounds 1 and 3 (each within the scatter of the next).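

In this assay, the change from 4-chlorophenyl to propyl on a saturated chain carbon, three bonds along the chain from an amine nitrogen in a ring, gives an 11-fold higher number from compound 2 to compound 3 (1.04 log units; beyond the scatter). Among the compounds shown here, this is the first single-place step, and it shows that, on the core of compound 2, this position does not tolerate the swap: read one bond further out, the 3-(4-chlorophenyl)propyl group outperforms hexyl by a large margin. Nothing measured explains the size of this step.

From the compounds shown here alone, it remains open whether the difference follows the ring or the chlorine, a question that phenyl or cyclohexyl at this place would help to separate. Compound 1 differs from compound 2 and compound 3 in more than one place, so it cannot settle this.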